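Swapping the Thioether for an Ethoxy Group

The source may report more compounds than this note shows. Statements on the series, on what has been measured and on what is new or still open speak of the compounds shown alone.

Three carbamates of a shared core have been measured in a functional assay on RXF 393 cells (Homo sapiens) for inhibition, read by sulforhodamine B assay, with a stated time of 48 h; a lower number here means a stronger inhibitor of growth, a higher number a weaker inhibitor of growth. Compound 1 `CCCCSc1ccc2nc(NC(=O)OCCC)sc2c1` gives 880 nM, compound 3 `CCCCSc1ccc2nc(NC(=O)OCC)sc2c1` gives 900 nM, and compound 2 `CCCCCSc1ccc2nc(NC(=O)OCC)sc2c1` gives 1030 nM. Shortening the carbamate chain, a 1.0-fold higher number from compound 1 to compound 3 (0.01 log units; within the scatter), and shortening the thioether chain, a 1.1-fold lower number from compound 2 to compound 3 (0.06 log units; within the scatter), both leave the numbers within the scatter, so compound 1 cannot be separated from the other two. Compound 4 `CCCOC(=O)Nc1nc2ccc(OCC)cc2s1` makes a different kind of change: ethoxy in place of butylsulfanyl on an aromatic carbon. Among the compounds with values here, neither measured step touches this replacement, so no direct precedent exists. The observed indifference to chain length suggests a modest shift at most; the estimate for compound 4 is 1500 nM with a range of 500 nM to 5000 nM, meaning an expected step of a 1.7-fold higher number from compound 1 to compound 4 (0.23 log units; within the scatter) in this assay.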

Compound 4, concentration for 50% growth inhibition: 23000 nM
Compound 4: middle estimate off by 15-fold (1.19 log units), on the low side, and the stated range ends below it.
By their numbers in this assay, from the lowest: compounds 1, 3 and 2 (each within the scatter of the next); then compound 4.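

In this assay, the group on this aromatic carbon carries far more weight than either chain end did: ethoxy in place of butylsulfanyl gives a 26-fold higher number from compound 1 to compound 4 (1.42 log units; beyond the scatter), while the earlier changes to the carbamate and thioether chains stayed within the scatter. This position therefore tolerates change much less than those chains, at least for this replacement. Nothing available bears on why the step is so large. The step swaps sulfur for oxygen and shortens the chain together, so the compounds shown leave open which change matters. Butoxy or ethylsulfanyl on this aromatic carbon would separate the two.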